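Alkylsulfanyl chain extension on the shared core

This account rests on a few compounds, and the source may have more. Where it says the series, first, only, none or still open, it means among the compounds named here.

The series carries a methylsulfanyl, an ethylsulfanyl and a propylsulfanyl group on one shared core. Compound 1 is `CSc1nnc(COc2cc(C)c3c(C)cc(=O)oc3c2)o1`, compound 2 is `CCSc1nnc(COc2cc(C)c3c(C)cc(=O)oc3c2)o1`, and compound 3, still to be measured, is `CCCSc1nnc(COc2cc(C)c3c(C)cc(=O)oc3c2)o1`.

In a functional assay on MDA-MB-231 cells (Homo sapiens) for antiproliferative activity, read by MTT assay, with a stated time of 24 h (a lower number here means a stronger inhibitor, a higher number a weaker inhibitor), compound 1 gives > 100000 nM, which is a limit of the assay and not a number. In this assay compound 2 gives > 100000 nM, again a limit and not a number. The step from compound 1 to compound 2 is therefore a step that the two limits leave unreadable from compound 1 to compound 2. Compound 2 thus stands only at a limit, and the whole picture so far is the limit of > 100000 nM in this assay, at which 2 of the 2 values shown sit.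

Compound 3 differs from compound 2 by methyl in place of hydrogen on a saturated chain carbon, two bonds along the chain from a sulfur. For the measured compounds named here, the one measured step that bears on this change, the methyl-to-ethyl step from compound 1 to compound 2, could not be read, so no size is available for the homologous step. With both measured compounds sitting at the same limit, compound 3 is expected to stay at or beyond that limit as well, a step that the limit leaves unreadable from compound 2 to compound 3 from compound 2 that means no change beyond the scatter. Compound 3 is accordingly estimated at 150000 nM in this assay, within a range of 50000 nM to 500000 nM.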

Compound 3, half-maximal inhibitory concentration: > 100000 nM
Compound 3: a limit, no number; the forecaster's own chance of this, stated with the estimate: 85%; the middle value lies beyond the limit too.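

In this assay compound 3 gives > 100000 nM, a limit of the assay and not a number. No step among compound 1, compound 2 and compound 3 can be read, as all three stand at the same limit: the limit of > 100000 nM in this assay, at which 3 of the 3 values shown sit.

The compounds shown leave open whether chain length on the shared core affects activity in this assay at all.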